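Anilino variation on the shared core: compound 3

This account rests on a few compounds, and the source may have more. Where it says the series, first, only, none or still open, it means among the compounds named here.

Notes on the shared core, with `COc1ccccc1Nc1nc(-c2cccc(F)c2)nc2ccc(F)cc12` as compound 1. In a functional assay on MDA-MB-231 cells (Homo sapiens) for cytotoxicity, read by MTT assay, with a stated time of 48 h (a lower number here means a stronger inhibitor, a higher number a weaker inhibitor), compound 1 reaches only the limit of the assay, > 50000 nM. That standing is recorded as the limit of > 50000 nM in this assay, at which 1 of the 2 values shown sits. Compound 2, `Fc1cccc(Nc2nc(-c3cccc(F)c3)nc3ccc(F)cc23)c1`, carries 3-fluorophenyl in place of 2-methoxyphenyl on a nitrogen on an aromatic ring and gives 47600 nM in this assay; the step of an at least 1.0-fold lower number from compound 1 to compound 2 (0.02 log units; that floor lies within the scatter) lies within the scatter. Compound 3, `Cc1cccc(Nc2nc(-c3cccc(F)c3)nc3ccc(F)cc23)c1`, is not yet measured in this assay. Its change from compound 1 is 3-methylphenyl in place of 2-methoxyphenyl on a nitrogen on an aromatic ring. Among the measured compounds shown here, the only measured step that bears on it, an at least 1.0-fold lower number from compound 1 to compound 2 (0.02 log units; that floor lies within the scatter), shows that exchanging 2-methoxyphenyl for 3-fluorophenyl left the number at the limit or close to it, so no step beyond the scatter is expected in this assay. Compound 3 is therefore expected to give about 50000 nM, between 25000 nM and 100000 nM. The expected step is a number no higher from compound 1 to compound 3 (the limit leaves the size open), with a real chance that only a limit is returned again.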

Compound 3, half-maximal inhibitory concentration: > 50000 nM
Compound 3 was reported as a limit; the forecaster's own chance of this, stated with the estimate: 55%; the middle value lies on the limit itself.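

In this assay compound 3 gives > 50000 nM, which is a limit of the assay and not a number. Methyl in place of fluoro on an aromatic carbon gives an at least 1.0-fold higher number from compound 2 to compound 3 (0.02 log units; that floor lies within the scatter), so 3-methylphenyl and 3-fluorophenyl are not told apart here, while the step from compound 1 to compound 3 cannot be read. With a third aryl group on this nitrogen, 2-methoxyphenyl, 3-fluorophenyl and 3-methylphenyl still show no step beyond the scatter, and the readable range is barely reached: the limit of > 50000 nM in this assay, at which 2 of the 3 values shown sit.

Open, from the compounds shown here alone, is whether any group on this nitrogen brings the series well inside the readable range, for instance a phenyl ring carrying an amine or a carboxylic acid, or a longer chain in place of the methyl. The compounds shown also keep the rest of the shared core fixed, so its share in this result stays unknown.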